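The source may report more compounds than this note shows. Statements on the series, on what has been measured and on what is new or still open speak of the compounds shown alone.

Measured compounds: compound 1 `CSc1nc2c(C)nsc2[nH]1` gives 26000 nM in a functional assay on HFF cells (Homo sapiens) for inhibition; a lower number here means a stronger inhibitor, a higher number a weaker inhibitor; compound 2 `CSc1nc2cnsc2[nH]1` gives 32000 nM; compound 3 `CSc1nc2snc(C)c2n1[C@H]1C[C@H](O)[C@@H](CO)O1` gives 32000 nM.

From compound 1 to compound 2 the change is hydrogen in place of methyl on an aromatic carbon and it gives a 1.2-fold higher number from compound 1 to compound 2 (0.09 log units; within the scatter). The cores of compound 1 and compound 3 differ, but that difference is not broken down here. Compound 4 `CSc1nc2sncc2n1[C@H]1C[C@H](O)[C@@H](CO)O1` differs from compound 3 by hydrogen in place of methyl on an aromatic carbon, the same change, made at a place described in the same words. For compound 4 a step of a 1.1-fold higher number from compound 3 to compound 4 (0.05 log units; within the scatter) is expected in this assay, resting on the earlier step because a 1.2-fold higher number from compound 1 to compound 2 (0.09 log units; within the scatter) stayed within the scatter. Compound 4 is therefore estimated at 36000 nM, with a likely range from 18000 nM to 72000 nM.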

Compound 4, half-maximal inhibitory concentration: 15000 nM
The estimate for compound 4 lay 2.4-fold (0.38 log units) above the measured number; the measured number lies below the stated range.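

In this assay, hydrogen in place of methyl on the core of compound 3 gives a 2.1-fold lower number from compound 3 to compound 4 (0.33 log units; beyond the scatter), a modest step beyond the scatter. Set beside the same change on the core of compound 1, this step cannot be told apart from the earlier one: the same change on two cores in this assay, a 1.2-fold higher number (0.09 log units; within the scatter) from compound 1 to compound 2 and a 2.1-fold lower number (0.33 log units; beyond the scatter) from compound 3 to compound 4, 2.6-fold (0.42 log units) apart, within the scatter of two such steps

For the compounds shown here, the two cores therefore give no firm sign that the change behaves differently from one to the other, but this does not show that its effect carries over unchanged, as each core offers only a single pair. From the compounds shown here alone, whether an ethyl group, a chlorine atom or an amine on this aromatic carbon would shift the number on either core remains open.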